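Removing a Methoxy Group from a Chloroquinoline Styrene Series

The compounds below may be only part of what the source reports. "The series", "measured", "known", "first", "only" and "open" are said of these compounds alone.

Compound 1, `Fc1ccc(/C=C\c2cc3ccccc3nc2Cl)cc1`: 5290 nM
Compound 2, `COc1ccc2nc(Cl)c(/C=C\c3ccc(F)cc3)cc2c1`: 15200 nM
Compound 3, `COc1ccc2nc(Cl)c(/C=C\c3cc(C(F)(F)F)cc(C(F)(F)F)c3)cc2c1`: 5790 nM

Three compounds were measured in a functional assay on MDA-MB-468 cells (Homo sapiens) for antiproliferative activity, read by sulforhodamine B assay, with a stated time of 72 h; on this read-out lower numbers stand for stronger inhibition and higher numbers for weaker inhibition. Compound 2 gives 15200 nM, compound 1 gives 5290 nM, and compound 3 gives 5790 nM. Compound 1 and compound 3 lie within the scatter of each other, so no order between them is claimed; compound 2 stands beyond the scatter from both.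

Compound 1 is made from compound 2 by a single change, (hydrogen in place of methoxy on an aromatic carbon). That change gave a 2.9-fold lower number from compound 2 to compound 1 (0.46 log units; beyond the scatter).

Compound 4, `FC(F)(F)c1cc(/C=C\c2cc3ccccc3nc2Cl)cc(C(F)(F)F)c1`, has not yet been measured in this assay. It is made from compound 3 by the change (hydrogen in place of methoxy on an aromatic carbon). The place of this change is the same, word for word, as in the step from compound 2 to compound 1, so it is the same change made on a different core. How the core of compound 3 differs from that of compound 2 is not broken down here.

Among the compounds with values here, with only one earlier example of the change, the expectation rests on that single step. Because compound 3 gives 5790 nM and the earlier step was a 2.9-fold lower number from compound 2 to compound 1 (0.46 log units; beyond the scatter), the step from compound 3 to compound 4 is expected to be about a 2.6-fold lower number from compound 3 to compound 4 (0.42 log units; beyond the scatter), a modest one in the same direction. Compound 4 is therefore estimated at 2200 nM, with a range from 900 nM to 5500 nM that allows for the change transferring only partly to the new core.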

Compound 4, half-maximal inhibitory concentration: 10500 nM
The estimate for compound 4 lay 4.8-fold (0.68 log units) below the measured number, outside the stated range (above it).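

In this assay, within the data shown here, hydrogen in place of methoxy on an aromatic carbon gave a 1.8-fold higher number from compound 3 to compound 4 (0.26 log units; within the scatter), so on this second pair the change produced no step that can be told apart from the usual variation between repeated measurements. Among these compounds, the change therefore did not carry over from one core to the other with the size it had on the first pair, and the two steps differ by more than their scatter allows: the same change on two cores in this assay, a 2.9-fold lower number (0.46 log units; beyond the scatter) from compound 2 to compound 1 and a 1.8-fold higher number (0.26 log units; within the scatter) from compound 3 to compound 4, 5.2-fold (0.72 log units) apart, beyond the scatter of two such steps This does not show why the two steps differ, since each core supplies only one pair, and it gives no direction for the change on the second core; nor can two pairs show how the change would behave on any other core.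

The compounds shown leave open whether the gap between the two steps would hold up on further cores carrying other substituents on the styrene aromatic ring, such as a nitrile or a single trifluoromethyl group. They also leave open what would happen if the same aromatic carbon carried something other than methoxy or hydrogen, such as a hydroxyl group, an amine or a longer ether chain like ethoxy.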